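This account rests on a few compounds, and the source may have more. Where it says the series, first, only, none or still open, it means among the compounds named here.

Going by the values given here, in an ADME assay on J774.A1 cells (Mus musculus) for inhibition, read by MTT assay, with a stated time of 72 h (a lower number here means that less compound is needed, a higher number that more compound is needed for the effect), only one of three related compounds has so far given a number. Compound 1 (`Cc1ccccc1-c1nc(NCc2ccccc2)c2ccccc2n1`) stands at "not determined" (no result reported). Compound 2 (`CNc1nc(NCc2ccco2)nc2ccccc12`) likewise stands at "not determined" (no result reported). Compound 3 (`CC(C)Nc1nc(Nc2ccccc2)c2ccccc2n1`) gives 12000 nM, and with no other figure beside it, this value cannot be ranked against anything.

Compound 4 (`CC(C)Nc1nc(NC2CC2)c2ccccc2n1`) differs from compound 3 in one place, carrying cyclopropyl in place of phenyl on a nitrogen on an aromatic ring, anilino to cyclopropylamino: cyclopropyl in place of phenyl on a nitrogen on an aromatic ring. Among the compounds with values here, no measured pair shows what such a change does, so the only anchor is compound 3 at 12000 nM, and the expectation is a loose one. In this assay the expected change is a 1.5-fold higher number from compound 3 to compound 4 (0.18 log units; within the scatter), a small shift towards more compound being needed that is estimated to stay within the usual scatter. For compound 4 the estimated value is 18000 nM, with an expected range from 6000 nM to 50000 nM.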

Compound 4, half-maximal effective concentration: 31000 nM
Compound 4: middle estimate off by 1.7-fold (0.24 log units), on the low side; the range from low to high includes it.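

With phenyl leaving and cyclopropyl entering on a nitrogen on an aromatic ring, this assay shows a 2.6-fold higher number from compound 3 to compound 4 (0.41 log units; beyond the scatter), so this position is not indifferent to the group it carries, something a single number could not show. In this one pair, the anilino compound needs less compound for the effect than the cyclopropylamino compound, although a single step gives a direction for this change only and no general trend. Nothing at hand explains the shift. The compounds shown leave open how a longer alkyl chain, a hydroxyethyl group or a carboxylic acid on the same nitrogen would compare with phenyl and cyclopropyl. They also leave open whether the same exchange would give a step of similar size elsewhere on the shared core.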